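Chain-end variants on the shared core

This account rests on a few compounds, and the source may have more. Where it says the series, first, only, none or still open, it means among the compounds named here.

Compound 1 `O=C(O)CCCO/N=c1/ccn([C@@H]2O[C@H](COP(=O)(O)OP(=O)(O)OP(=O)(O)O)[C@@H](O)[C@H]2O)c(=O)[nH]1` carries a carboxy at the chain end. In a functional assay on 1321-N1 cells for agonist activity at P2Y purinoceptor 2 (Homo sapiens), read by scintillation counting and inositol phosphate accumulation (on this read-out higher numbers stand for an effect only at larger amounts of compound and lower numbers for an effect already at smaller amounts), compound 1 gives 299 nM, the second highest of the three numbers shown; compound 3 `O=c1[nH]/c(=N\OCCCc2cccc(I)c2)ccn1[C@@H]1O[C@H](COP(=O)(O)OP(=O)(O)OP(=O)(O)O)[C@@H](O)[C@H]1O` gives 325 nM and compound 2 `O=c1[nH]/c(=N\OCCCCc2ccccc2)ccn1[C@@H]1O[C@H](COP(=O)(O)OP(=O)(O)OP(=O)(O)O)[C@@H](O)[C@H]1O` gives 214 nM. Compound 4 `O=c1[nH]/c(=N\OCCCc2ccc(I)cc2)ccn1[C@@H]1O[C@H](COP(=O)(O)OP(=O)(O)OP(=O)(O)O)[C@@H](O)[C@H]1O` differs from compound 1 by 4-iodophenyl in place of carboxy on a saturated chain carbon, three bonds along the chain from an oxygen on an unsaturated carbon. Going by the values given here, the steps that bear on this change are a 1.4-fold lower number from compound 1 to compound 2 (0.15 log units; within the scatter) and a 1.1-fold higher number from compound 1 to compound 3 (0.04 log units; within the scatter), both within the scatter, and between the two aryl chain ends a 1.5-fold higher number from compound 2 to compound 3 (0.18 log units; within the scatter). Among the compounds with values here, no step in this set moves the number beyond the scatter, so for compound 4 no change beyond the scatter is expected in this assay, meaning a 1.0-fold higher number from compound 1 to compound 4 (0.00 log units; within the scatter). Compound 4 is therefore estimated at 300 nM, with a range from 150 nM to 600 nM.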

Compound 4, half-maximal effective concentration: 187 nM
Compound 4: the middle estimate sits 1.6-fold (0.21 log units) above what was measured; the range from low to high includes it.
By their numbers in this assay, from the lowest: compounds 4, 2, 1 and 3 (each within the scatter of the next).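

The 4-iodophenyl chain end in place of 3-iodophenyl gives a 1.7-fold lower number from compound 3 to compound 4 (0.24 log units; within the scatter), so the two iodophenyl groups are not told apart in this assay. Set against the other two chain ends, it gives a 1.6-fold lower number from compound 1 to compound 4 (0.20 log units; within the scatter) and a 1.1-fold lower number from compound 2 to compound 4 (0.06 log units; within the scatter), so all four chain ends at this place on a saturated chain carbon remain within the scatter of one another. No supporting data on this position accompany these numbers.

Going by these compounds, whether an amine, a hydroxyl or a 4-fluorophenyl at this place would move the number beyond the scatter stays open.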